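Cyano for chloro on the shared core

The compounds below may be only part of what the source reports. "The series", "measured", "known", "first", "only" and "open" are said of these compounds alone.

Compound 1 `Cc1cc(-c2ccnc(C(F)F)c2)ncc1OC[C@@](C)(N)CC(C)C`, compound 2 `COC(=O)Nc1cc(-c2cnc(OC[C@@](C)(N)CC(C)C)c(OC)c2)ccn1` and compound 3 `COC(=O)Nc1cc(-c2cnc(OC[C@@](C)(N)CC(C)C)c(Cl)c2)ccn1` have all been tested in an ADME assay on microsomes from liver (Rattus norvegicus) for metabolic stability, read by LC-MS, using NADPH, with a stated time of 10 min, tested at 0.5 uM; a lower number here means that less of the compound is left, a higher number that more of the compound is left. Compound 1 gives 76%, compound 2 gives 79% and compound 3 gives 73%. Among the measured compounds shown here, the one single-point step among them, a number 6 percentage points lower from compound 2 to compound 3 (within the scatter), stays inside the scatter, so the three numbers cannot be told apart. Compound 3 stands with the lowest of the three numbers, with compound 1 nearest and compound 2 furthest, both within the scatter.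

Compound 4 `COC(=O)Nc1cc(-c2cnc(OC[C@@](C)(N)CC(C)C)c(C#N)c2)ccn1` is not yet measured and differs from compound 3 in one place: cyano in place of chloro on an aromatic carbon. For the measured compounds named here, the only measured step that bears on it is the swap at the same position, a number 6 percentage points lower from compound 2 to compound 3 (within the scatter), and that step was within the scatter. On that basis no step beyond the scatter is expected for compound 4, in either direction. Compound 4 is therefore estimated to give 75%, with a range from 60% to 88%. The expected step is a number 2 percentage points higher from compound 3 to compound 4 (within the scatter).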

Compound 4, percent of the compound remaining: 80%
Compound 4: middle estimate off by 5 percentage points, on the low side, within the range that was stated.
By their numbers in this assay, from the lowest: compounds 3, 1, 2 and 4 (each within the scatter of the next).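

In this assay, cyano in place of chloro gives a number 7 percentage points higher from compound 3 to compound 4 (within the scatter) and cyano in place of methoxy gives a number 1 percentage points higher from compound 2 to compound 4 (within the scatter) on the same shared core. With chloro, methoxy and cyano now all seen on this aromatic carbon, ortho to a (2-amino-2,4-dimethylpentyl)oxy group, every step among the three stays within the scatter, so this read-out does not tell these groups apart at this position. No evidence at hand bears on why the numbers behave this way.

Still open, as far as these compounds go, is whether an amine, a carboxylic acid or a trifluoromethyl group on this carbon would give a step beyond the scatter. The compounds shown also leave open whether cyano would give a similar number with a different group in place of the (2-amino-2,4-dimethylpentyl)oxy chain.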